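The compounds below may be only part of what the source reports. "The series", "measured", "known", "first", "only" and "open" are said of these compounds alone.

In a functional assay on DU-145 cells (Homo sapiens) for cytotoxicity, read by MTT assay, with a stated time of 68 h (on this read-out higher numbers stand for weaker inhibition and lower numbers for stronger inhibition), three compounds have been measured:

Compound 1 `O=C(/C=C/c1cccc(OCc2ccccc2)c1)c1ccc(Br)cc1` gives 5700 nM
Compound 2 `Cc1ccc(C(=O)/C=C/c2cccc(OCc3ccccc3)c2)cc1` gives 25600 nM
Compound 3 `O=C(/C=C/c1cccc(OCc2ccccc2)c1)c1ccccc1` gives 42400 nM

Compound 2 stands at the high end of these numbers: a 1.7-fold higher number from compound 2 to compound 3 (0.22 log units; within the scatter) stays within the scatter, whereas a 4.5-fold higher number from compound 1 to compound 2 (0.65 log units; beyond the scatter) goes beyond it.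

Compound 4 `COc1ccc(C(=O)/C=C/c2cccc(OCc3ccccc3)c2)cc1` is the next to be measured, and it differs from compound 2 by one exchange methoxy in place of methyl on an aromatic carbon with methoxy in place of methyl on an aromatic carbon. Among the compounds with values here, no measured step involves methoxy, so the evidence is indirect. Exchanges on this same carbon ranged from a 1.7-fold higher number from compound 2 to compound 3 (0.22 log units; within the scatter) for hydrogen in place of methyl to a 7.4-fold higher number from compound 1 to compound 3 (0.87 log units; beyond the scatter) for hydrogen in place of bromo. Only bromo moved the number beyond the scatter. In this assay a small step is therefore expected, probably none beyond the scatter, with no firm direction. The expected step is a 1.2-fold lower number from compound 2 to compound 4 (0.07 log units; within the scatter) as an estimate. For compound 4 the estimated value is 22000 nM with an expected range from 8000 nM to 50000 nM.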

Compound 4, half-maximal inhibitory concentration: 51300 nM
Estimate against measurement, compound 4: 2.3-fold (0.37 log units) below; measured number above the stated range.
By their numbers in this assay, from the lowest: compound 1; then compounds 2, 3 and 4 (each within the scatter of the next).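

Methoxy in place of methyl on this aromatic carbon gives a 2.0-fold higher number from compound 2 to compound 4 (0.30 log units; within the scatter), and methoxy in place of hydrogen gives a 1.2-fold higher number from compound 3 to compound 4 (0.08 log units; within the scatter), so in this assay the hydrogen, methyl and methoxy compounds cannot be told apart, even though methoxy brings a hydrogen-bond acceptor that the other two lack. Bromo alone remains set apart, and the new comparison gives a 9.0-fold higher number from compound 1 to compound 4 (0.95 log units; beyond the scatter), adding to the two earlier steps that separate compound 1 from the rest. Nothing available here explains why bromo differs from the other three groups.

With bromo as the only halogen shown, it remains open whether chloro or iodo on this carbon would match compound 1. As far as these compounds go, it is equally open whether an amine or a carboxylic acid there would stay with compounds 2, 3 and 4.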